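Swapping the Amine Substituent on the Core of Compound 1

This account rests on a few compounds, and the source may have more. Where it says the series, first, only, none or still open, it means among the compounds named here.

The compounds here share one core and are compared in an assay on isolated protein for inhibition of DNA topoisomerase 1 (Homo sapiens), with a stated time of 30 min, tested at 20 uM; on this read-out higher numbers stand for a stronger effect at the one concentration tested and lower numbers for a weaker effect. Among the compounds with values here, compound 1 `O=c1[nH]c(-c2cccc3ccccc23)nc2ccc(N3CCCCC3)cc12` gives 33.4% and stands highest of the three numbers measured so far; compound 3 `Cc1ccc2nc(-c3cccc(F)c3)[nH]c(=O)c2c1` is the nearest with 0.2%, and compound 2 `Cc1ccc2nc(-c3cccc(OC(F)(F)F)c3)[nH]c(=O)c2c1` the furthest with 0%, both gaps lying beyond the scatter. Within the data shown here, the single step between measured compounds that differ in one place, a number 0.2 percentage points higher from compound 2 to compound 3 (within the scatter), concerns a fluoro in place of trifluoromethoxy on an aromatic carbon elsewhere in the molecule, and it lies within the scatter.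

Compound 4 `CN(C)c1ccc2nc(-c3cccc4ccccc34)[nH]c(=O)c2c1` is not yet measured. It differs from compound 1 in one place: dimethylamino in place of piperidin-1-yl on an aromatic carbon. Among the measured compounds shown here, no measured step touches this kind of change: the only step in hand concerns a different ring and a different pair of groups, so it gives no guide to the size or direction of what is expected here. For the measured compounds named here, the leaving group is a ring of six heavy atoms, the entering one a chain of three, and nothing among the measured compounds shows what such a change does. The step is therefore expected to be small, a number 5.4 percentage points lower from compound 1 to compound 4 (within the scatter), with no confident direction. Compound 4 is estimated at 28%, within a range from 10% to 48%.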

Compound 4, a percentage reported as inhibition, at one concentration (the size of the read-out at that concentration, not a potency): 2.4%
Beside the measured number, compound 4's estimate is 25.6 percentage points above it, outside the stated range (below it).
By their numbers in this assay, from the lowest: compounds 2, 3 and 4 (each within the scatter of the next); then compound 1.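

With the rest of the molecule unchanged, dimethylamino in place of piperidin-1-yl on this aromatic carbon gives a number 31 percentage points lower from compound 1 to compound 4 (beyond the scatter) in this assay, so the group at this position can strongly change the effect seen at the one concentration tested. The two groups match in their counts of hydrogen-bond donors and acceptors and in having no net charge; what separates them is that piperidin-1-yl has a six-membered non-aromatic ring and more heavy atoms, so the drop goes with those differences, although this single pair cannot tell which of them matters. Nothing measured here on the compounds themselves accounts for the size of this step.

As far as these compounds go, it remains open whether the ring itself or simply the number of heavy atoms counts: diethylamino, an open-chain group, and pyrrolidin-1-yl, a smaller ring, would help to separate the two. From the compounds shown here alone, it is equally open whether a ring with a second hetero atom, such as morpholin-4-yl, would keep the number of compound 1, and whether the same swap would have a similar effect with a different aromatic group elsewhere on the shared core.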